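Swapping the halogenated phenyl ring on the core

This account rests on a few compounds, and the source may have more. Where it says the series, first, only, none or still open, it means among the compounds named here.

Measured compounds in a functional assay on PC-3 cells (Homo sapiens) for cytotoxicity, read by MTT assay, with a stated time of 72 h; a higher number here means a weaker inhibitor, a lower number a stronger inhibitor:
- Compound 1, `O=C(Nc1ccc(Oc2ccnc3[nH]ccc23)cc1)c1nn(-c2ccc(Cl)cc2)ccc1=O`, gives 32400 nM.
- Compound 2, `O=C(Nc1ccc(Oc2ccnc3[nH]ccc23)cc1)c1nn(-c2ccc(Cl)c(C(F)(F)F)c2)ccc1=O`, gives 4630 nM.
- Compound 3, `O=C(Nc1ccc(Oc2ccnc3[nH]ccc23)c(F)c1)c1nn(-c2ccc(Cl)cc2)ccc1=O`, gives 42500 nM.

All three share one core, and compound 3 gives the highest number of the three in this assay; against compound 1 the gap is small, a 1.3-fold higher number from compound 1 to compound 3 (0.12 log units; within the scatter), while against compound 2 it is large, a 7.0-fold lower number from compound 1 to compound 2 (0.84 log units; beyond the scatter) from compound 1 alone.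

Compound 4, `O=C(Nc1ccc(Oc2ccnc3[nH]ccc23)c(F)c1)c1nn(-c2ccc(Br)cc2F)ccc1=O`, differs from compound 3 in one place: 4-bromo-2-fluorophenyl in place of 4-chlorophenyl on an aromatic nitrogen. For the measured compounds named here, no measured step exchanges one halogen for another on this ring, so only indirect guidance exists. The step of a 7.0-fold lower number from compound 1 to compound 2 (0.84 log units; beyond the scatter) shows that adding a group to this ring can lower the number by a modest amount, and the step of a 1.3-fold higher number from compound 1 to compound 3 (0.12 log units; within the scatter) shows that a fluoro on the other ring changed little. Because of a 7.0-fold lower number from compound 1 to compound 2 (0.84 log units; beyond the scatter) a small downward move is expected, a 1.7-fold lower number from compound 3 to compound 4 (0.23 log units; within the scatter), but with wide uncertainty. Compound 4 is estimated at 25000 nM, ranging from 8000 nM to 80000 nM.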

Compound 4, half-maximal inhibitory concentration: 8800 nM
Beside the measured number, compound 4's estimate is 2.8-fold (0.45 log units) above it; the measured number falls inside the stated range.
By their numbers in this assay, from the lowest: compounds 2 and 4 (each within the scatter of the next); then compounds 1 and 3 (each within the scatter of the next).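

In this assay, 4-bromo-2-fluorophenyl in place of 4-chlorophenyl on the aromatic nitrogen gives a clear drop (a 4.8-fold lower number from compound 3 to compound 4 (0.68 log units; beyond the scatter)), so changing this ring can lower the number even when the other ring carries a fluoro, and not only on the core of compound 1. The swap makes two changes at once, a bromo for the chloro and an added fluoro, and the compounds shown cannot divide the drop between them. No measurement here explains the drop.

From the compounds shown here alone, it remains open whether the bromo or the added fluoro matters more, and whether 4-bromo-2-fluorophenyl would lower the number on the core of compound 1 as well. Going by these compounds, how an amine or a carboxylic acid on this phenyl ring would behave also remains open.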